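A few compounds are considered here, and "the series" means these few. Any claim that something is new, unique, unknown or untested is made for them only; others in the source may bear on it.

Compound 1 `COc1cc(/C=C/C(=O)c2sc(Nc3ccc(Cl)c(Cl)c3)nc2C)cc(OC)c1OC`: 19300 nM
Compound 2 `COc1cc(/C=C/C(=O)c2sc(Nc3ccc(C)cc3)nc2C)cc(OC)c1OC`: > 25000 nM

In a functional assay on PC-3 cells (Homo sapiens) for cytotoxicity, read by MTT assay (a higher number here means a weaker inhibitor, a lower number a stronger inhibitor), compound 1 gives 19300 nM. For compound 2 the result is only a limit, > 25000 nM. Within the data shown here, the single measured step, an at least 1.2-fold higher number from compound 1 to compound 2 (0.11 log units; that floor lies within the scatter), therefore has only a floor. Compound 3 `COc1cc(/C=C/C(=O)c2sc(Nc3cccc(C)c3)nc2C)cc(OC)c1OC` differs from compound 2 by 3-methylphenyl in place of 4-methylphenyl on a nitrogen on an aromatic ring. Among the measured compounds shown here, no measured step exchanges one methylphenyl for another, and the measured step bears on this change only through compound 2 sitting at the limit of > 25000 nM in this assay, at which 1 of the 2 values shown sits. Compound 3 is expected to show a step that the limit leaves unreadable from compound 2 to compound 3, not beyond the scatter. Compound 3 is estimated at 28000 nM, within 12000 nM to 70000 nM.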

Compound 3, half-maximal inhibitory concentration: > 25000 nM
Compound 3: a limit, no number; the forecaster's own chance of this, stated with the estimate: 60%; the middle value lies beyond the limit too.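

In this assay the result for compound 3 is again only a limit: > 25000 nM. The exchange of 4-methylphenyl for 3-methylphenyl on the nitrogen therefore cannot be read, so neither placing of the methyl can be ranked against the other. Among these compounds, the one readable new step is an at least 1.2-fold higher number from compound 1 to compound 3 (0.11 log units; that floor lies within the scatter), and it sets no order between 3-methylphenyl and 3,4-dichlorophenyl, with the readings gathering at one limit: the limit of > 25000 nM in this assay, at which 2 of the 3 values shown sit.

Going by these compounds, whether the two methylphenyl compounds differ at all stays open. So does what a carboxylic acid or an amine in place of the methyl would give.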